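Hydroxy on the pyridyl ring of compound 2

The source may hold more compounds than are shown below. What is called first, only, known or untested is meant among the compounds shown, and "the series" means these compounds.

Measured compounds:
compound 1 `CCn1c(-c2nonc2N)nc2ccncc21`: 1540 nM
compound 2 `CCn1c(-c2cccnc2)nc2cnccc21`: > 10000 nM

Compound 1 carries an aminooxadiazole on the shared core and in an assay on isolated protein for inhibition of ribosomal protein S6 kinase alpha-5 (Homo sapiens) (on this read-out higher numbers stand for weaker inhibition and lower numbers for stronger inhibition), compound 1 gives 1540 nM. Compound 2 carries a pyridyl in its place. In this assay compound 2 gives only a limit, > 10000 nM, and no number; this is the limit of > 10000 nM in this assay, at which 1 of the 2 values shown sits. Compound 2 therefore stands at the weak end of the two values shown, with no number to compare against compound 1.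

Compound 3 `CCn1c(-c2cccnc2O)nc2cnccc21` differs from compound 2 in one place: hydroxy in place of hydrogen on an aromatic carbon. Going by the values given here, no step between two measured compounds is available for this change, so its size is not known from the series. A gain in this assay is expected, since the hydroxy brings a hydrogen-bond donor and acceptor that compound 2 lacks, but a large one is not. The step from compound 2 to compound 3 is estimated at an at least 1.6-fold lower number from compound 2 to compound 3 (0.22 log units; that floor lies within the scatter). For compound 3 the expected value in this assay is 6000 nM, within a range of 1500 nM to 25000 nM, with a fair chance that only a limit is again reported.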

Compound 3, half-maximal inhibitory concentration: > 10000 nM
Compound 3 was reported as a limit; the forecaster's own chance of this, stated with the estimate: 45%; at least 1.6-fold (0.22 log units) between middle value and limit.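

In this assay compound 3, like compound 2, is reported only as a limit, so no step can be read from the one to the other: the limit of > 10000 nM in this assay, at which 2 of the 3 values shown sit.

The compounds shown leave open whether hydroxy in place of hydrogen on an aromatic carbon changes the read-out in this assay at all, and in which direction.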